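Swapping hydroxy for chloro on the aryl urea end

The compounds below may be only part of what the source reports. "The series", "measured", "known", "first", "only" and "open" are said of these compounds alone.

Compound 1 `COc1cc(NC(C)CCCNC(=O)NNC(=O)Nc2cc(C(F)(F)F)cc(C(F)(F)F)c2)c2ncccc2c1`: 2400 nM
Compound 2 `COc1cc(NC(C)CCCNC(=O)Nc2ccc(F)cc2)c2ncccc2c1`: 26000 nM
Compound 3 `COc1cc(NC(C)CCCNC(=O)NNC(=O)Nc2ccc(O)cc2)c2ncccc2c1`: 2600 nM

These three compounds share a core and were tested in a functional assay on MCF7 cells (Homo sapiens) for inhibition, read by MTT assay, with a stated time of 72 h; a lower number here means a stronger inhibitor, a higher number a weaker inhibitor. Compound 3 gives the second highest of the three numbers. Its value and that of compound 1 lie within the scatter of each other, so no order between them can be drawn. Within the data shown here, compound 2 stands furthest away, and the step of a 10-fold lower number from compound 2 to compound 3 (1.00 log units; beyond the scatter) is the only measured step with a single change; it alters both the linker and the aryl group at once.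

Compound 4 `COc1cc(NC(C)CCCNC(=O)NNC(=O)Nc2ccc(Cl)cc2)c2ncccc2c1` differs from compound 3 by a single change: chloro in place of hydroxy on an aromatic carbon. In the other words given for it, 4-hydroxyphenyl becomes 4-chlorophenyl.

Among the measured compounds shown here, no measured step changes this group alone on the same scaffold, so the direction cannot be read from the data. What the data do show is that compound 1, carrying a quite different aryl group on the same linker, lands within the scatter of compound 3. The step of a 1.0-fold lower number from compound 3 to compound 4 (0.02 log units; within the scatter) is therefore expected to stay within the scatter. Compound 4 is expected to give about 2500 nM, in the range 1000 nM to 6500 nM.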

Compound 4, half-maximal inhibitory concentration: 180 nM
Beside the measured number, compound 4's estimate is 14-fold (1.14 log units) above it, and the stated range ends above it.
By their numbers in this assay, from the lowest: compound 4; then compounds 1 and 3 (each within the scatter of the next); then compound 2.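

Among these compounds, this is the first measured step that changes only the group on the aromatic ring, and in this assay chloro in place of hydroxy gives a 14-fold lower number from compound 3 to compound 4 (1.16 log units; beyond the scatter) on the same linker. What sits on this six-membered aromatic ring of carbon only, para to a large group, therefore matters a great deal, even though compound 1 and compound 3, with different aryl groups, lie within the scatter of each other. The wider step a 140-fold lower number from compound 2 to compound 4 (2.16 log units; beyond the scatter) shows how far the series spans, but it changes the linker and the aryl end together, so it cannot be credited to the chloro group alone.

No measurement shown here accounts for the gain from hydroxy to chloro. As far as these compounds go, a fluoro, methyl, methoxy or amino group at this same place on the same linker would help show whether the result is particular to chloro or whether hydroxy is simply a poor fit for this assay, and a longer chain between the core and the aryl end remains untested in this set.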